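Swapping Isobutyl for Benzyl on a Weak Growth Inhibitor

The source may hold more compounds than are shown below. What is called first, only, known or untested is meant among the compounds shown, and "the series" means these compounds.

Of the compounds shown here, three built on the same core have been tested in a functional assay on HT-29 cells (Homo sapiens) for antiproliferative activity, read by MTT assay, with a stated time of 72 h; a lower number here means a stronger inhibitor of growth, a higher number a weaker inhibitor of growth. Compound 1 `Nc1cc(OCc2ccccc2)nc(SCc2ccccc2)n1` gives 53900 nM. Compound 3 `CC(=O)Nc1cc(=O)n(CC(C)C)c(SCc2ccccc2)n1` gives 68400 nM. For compound 2 `CC(C)Cn1c(SCc2ccccc2)nc(N)cc1=O` the result is only a limit of the assay, > 100000 nM, so no number is known for it. One measured step connects these: an at least 1.4-fold lower number from compound 2 to compound 3 (0.16 log units; that floor lies within the scatter), a change too small to count as a real difference. Compound 2 therefore stands at the weak end of what is shown, at the limit of > 100000 nM in this assay, at which 1 of the 3 values shown sits.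

Compound 4 `Nc1cc(=O)n(Cc2ccccc2)c(SCc2ccccc2)n1` differs from compound 2 in one place: phenyl in place of isopropyl on a saturated chain carbon bound to an aromatic nitrogen. For the measured compounds named here, none of the measured steps touches this chain on the aromatic nitrogen; the only measured step, the acetyl change from compound 2 to compound 3, lies elsewhere and stayed within the scatter. Compound 1, which carries benzyl groups but lacks the carbonyl, sits close to the limit as well. Going by the values given here, with no guiding step, compound 4 is expected to remain a weak inhibitor in this assay, with an estimated step of an at least 1.2-fold lower number from compound 2 to compound 4 (0.09 log units; that floor lies within the scatter). The estimate for compound 4 is 80000 nM, ranging from 30000 nM to 200000 nM.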

Compound 4, concentration for 50% growth inhibition: 100000 nM
Beside the measured number, compound 4's estimate is 1.3-fold (0.10 log units) below it; low and high end bracket the measured number.
By their numbers in this assay, from the lowest: compounds 1, 3 and 4 (each within the scatter of the next).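

For the compounds shown here, this is the first result for a change in the chain on the aromatic nitrogen, and it shows a number no higher from compound 2 to compound 4 (the limit leaves the size open). With benzyl in place of isobutyl, compound 4 gives 100000 nM in this assay, so this swap adds an aromatic ring at this position and yields a measured number, yet the compound remains a weak inhibitor of growth. For compound 2 there is only a limit of the assay, > 100000 nM, and the size of the step from isobutyl to benzyl cannot be read because that limit leaves it open: the limit of > 100000 nM in this assay, at which 1 of the 4 values shown sits.

The compounds shown leave open whether a different kind of group on this nitrogen, such as a longer chain like hexyl or a short chain ending in an amine or a carboxylic acid, would give a clearly lower number. They also leave open whether a benzyl ring carrying a further group, such as methoxy or chlorine, would change the result, and whether the acetyl group of compound 3 would have any effect in the presence of benzyl on this nitrogen.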